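The compounds below may be only part of what the source reports. "The series", "measured", "known", "first", "only" and "open" are said of these compounds alone.

Measured so far in a functional assay on A549 cells (Homo sapiens) for cytotoxicity, with a stated time of 48 h; on this read-out lower numbers stand for stronger inhibition and higher numbers for weaker inhibition:
Compound 1, `C[S+]([O-])/C=C/c1cc(=O)c2cc(O)ccc2o1`: compound 1 gives 10500 nM.
Compound 2, `C[S+]([O-])/C=C/c1cc(=O)c2cc(F)ccc2o1`: compound 2 gives 2100 nM.

Compound 2 stands lowest of the two numbers; compound 1 is its nearest neighbour, and the step of a 5.0-fold lower number from compound 1 to compound 2 (0.70 log units; beyond the scatter) lies beyond the scatter. Compound 3, `CCCOc1ccc2oc(/C=C/[S+](C)[O-])cc(=O)c2c1`, differs from compound 2 in one place: propoxy in place of fluoro on an aromatic carbon. For the measured compounds named here, the only measured step, a 5.0-fold lower number from compound 1 to compound 2 (0.70 log units; beyond the scatter), concerns hydroxy giving way to fluoro and does not bear directly on fluoro giving way to propoxy. The step of a 1.2-fold higher number from compound 2 to compound 3 (0.08 log units; within the scatter) is therefore expected to stay within the scatter. The estimate for compound 3 is 2500 nM, within 800 nM to 8000 nM.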

Compound 3, half-maximal inhibitory concentration: 1100 nM
Estimate against measurement, compound 3: 2.3-fold (0.36 log units) above; measured number inside the range.
By their numbers in this assay, from the lowest: compounds 3 and 2 (each within the scatter of the next); then compound 1.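

In this assay, this position on the aromatic carbon takes propoxy as well as fluoro, and a 1.9-fold lower number from compound 2 to compound 3 (0.28 log units; within the scatter) leaves the two compounds indistinguishable. Putting propyl on the oxygen of compound 1 gives a 9.5-fold lower number from compound 1 to compound 3 (0.98 log units; beyond the scatter), so a free hydroxy is not needed here and the larger group is tolerated. No evidence is available that accounts for either step.

On these data alone, whether a longer chain such as butoxy or a terminal amine on the propoxy chain would be tolerated here stays open.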